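A few compounds are considered here, and "the series" means these few. Any claim that something is new, unique, unknown or untested is made for them only; others in the source may bear on it.

Measured in a functional assay on RS4-11 cells (Homo sapiens) for inhibition, read by CCK-8 assay, with a stated time of 72 h; a lower number here means a stronger inhibitor, a higher number a weaker inhibitor:
compound 1 `CC1(C)CCC(CN2CCN(c3ccc(C(=O)NS(=O)(=O)c4ccc(NCC5CCOCC5)c([N+](=O)[O-])c4)c(Oc4cnc5[nH]ccc5c4)c3)CC2)=C(c2ccc(Cl)cc2C(F)(F)F)C1`: 74 nM
compound 2 `CC1(C)CCC(CN2CCN(c3ccc(C(=O)NS(=O)(=O)c4ccc(NCC5CCOC5)c([N+](=O)[O-])c4)c(Oc4cnc5[nH]ccc5c4)c3)CC2)=C(c2ccc(C(F)(F)F)cc2)C1`: 24.2 nM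

Of these two, compound 2 has the lower number, 24.2 nM, so it is the stronger inhibitor, and its gap to compound 1 lies beyond the usual scatter. Compound 3 `CC1(C)CCC(CN2CCN(c3ccc(C(=O)NS(=O)(=O)c4ccc(OCC5CCCOC5)c([N+](=O)[O-])c4)c(Oc4cnc5[nH]ccc5c4)c3)CC2)=C(c2ccc(C(F)(F)F)cc2)C1` has yet to be measured. It swaps one group of compound 2, on an aromatic carbon ortho to a nitro group: a group of 8 heavy atoms (6 carbon, 2 oxygen; one six-membered non-aromatic ring with 1 hetero atom) in place of a group of 7 heavy atoms (5 carbon, 1 nitrogen, 1 oxygen; one five-membered non-aromatic ring with 1 hetero atom), on an aromatic carbon. Among the compounds with values here, no measured pair differs in one place only, so the data give no direct guide. In this assay a modest rise in the number, meaning a weaker inhibitor, is expected, somewhat beyond the scatter. The expected change is a 2.5-fold higher number from compound 2 to compound 3 (0.39 log units; beyond the scatter). For compound 3 the estimated value is 60 nM, within an expected range of 15 nM to 240 nM.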

Compound 3, half-maximal inhibitory concentration: 12 nM
Compound 3: middle estimate off by 5.0-fold (0.70 log units), on the high side; the whole stated range lies above it.
By their numbers in this assay, from the lowest: compounds 3 and 2 (each within the scatter of the next); then compound 1.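

In this assay, the swap on the aromatic carbon ortho to a nitro group gives a 2.0-fold lower number from compound 2 to compound 3 (0.30 log units; within the scatter) and so leaves compound 2 and compound 3 indistinguishable. At this position, the ((oxolan-3-yl)methyl)amino group, with its hydrogen-bond donor, can therefore be replaced by a group with a six-membered ring and no donor without a clear loss of inhibition. Nothing available explains this result.

From the compounds shown here alone, the swap alters both the ring and the donor count, so their separate contributions remain open. A ((oxolan-3-yl)methyl)oxy group at this carbon would have the five-membered ring without the amine hydrogen.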